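Swapping the halogen on the phenyl ring of a hydroxamate

The source may hold more compounds than are shown below. What is called first, only, known or untested is meant among the compounds shown, and "the series" means these compounds.

Two members of this small series have been measured. Compound 1 `O=C(NO)c1coc(-c2ccccc2)n1` carries an unsubstituted phenyl ring on the shared core and in an assay on isolated protein for inhibition of histone deacetylase 8 (Homo sapiens), read by fluorescence, with a stated time of 90 min (a higher number here means a weaker inhibitor, a lower number a stronger inhibitor), compound 1 gives 41900 nM. Compound 2 `O=C(NO)c1coc(-c2ccc(Cl)cc2)n1` differs only by a chloro group on that ring, and in this assay compound 2 gives 30800 nM. The step of a 1.4-fold lower number from compound 1 to compound 2 (0.13 log units; within the scatter) falls within the scatter, so compound 2 stands alongside compound 1 rather than apart from it; both are weak inhibitors by the numbers seen.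

Compound 3 `O=C(NO)c1coc(-c2ccc(F)cc2)n1` is the next step: fluoro in place of chloro on an aromatic carbon. Among the compounds with values here, no measured pair exchanges one halogen for another, so the only step that bears on this change is the one from hydrogen to chloro at the same place, which was within the scatter. The expectation for compound 3 is therefore no step beyond the scatter in this assay, with a 1.2-fold higher number from compound 2 to compound 3 (0.07 log units; within the scatter) as the estimated move. Compound 3 is estimated at 36000 nM, with a range from 15000 nM to 90000 nM.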

Compound 3, half-maximal inhibitory concentration: 43400 nM
Beside the measured number, compound 3's estimate is 1.2-fold (0.08 log units) below it; measured number inside the range.
By their numbers in this assay, from the lowest: compounds 2, 1 and 3 (each within the scatter of the next).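

Within the data shown here, for the first time, one halogen is exchanged directly for another at this place, and the result is a 1.4-fold higher number from compound 2 to compound 3 (0.15 log units; within the scatter) in this assay with nothing to separate chloro from fluoro. Fluoro can also be set against plain hydrogen, where the step is a 1.0-fold higher number from compound 1 to compound 3 (0.02 log units; within the scatter) and again nothing separates the two, so none of these three groups on the aromatic carbon para to a group of 9 heavy atoms stands apart from the others. No measurement at hand speaks to what lies behind this flat picture.

From the compounds shown here alone, whether a group of a different kind at this place, such as an amine, a carboxylic acid or a longer alkyl chain, would move the number beyond the scatter stays open, as does whether any such group would lift these compounds out of the weak range seen so far. Also open, going by these compounds, is whether other places on the phenyl ring, or changes to the shared core or the hydroxamate, would respond any differently from this one.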